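Swapping Pyridyl for Fluorophenyl on a Thiazole Series

The source may hold more compounds than are shown below. What is called first, only, known or untested is meant among the compounds shown, and "the series" means these compounds.

Compound 1, `O=C(CN1CCN(c2ccc(F)cc2)CC1)Nc1nc2c(o1)CCCC2`: 5400 nM
Compound 2, `O=C(CN1CCN(c2ccncc2)CC1)Nc1nc2c(s1)CCCC2`: > 10000 nM
Compound 3, `O=C(CN1CCN(c2ccc(F)cc2)CC1)Nc1nc2c(s1)CCC2`: > 10000 nM

In an assay on isolated protein for inhibition of long-chain fatty acid transport protein 1 (Mus musculus), read by scintillation counting, with a stated time of 20 min (on this read-out higher numbers stand for weaker inhibition and lower numbers for stronger inhibition), compound 2 gives only a limit, (the limit of > 10000 nM in this assay, at which 2 of the 3 values shown sit), and not a number. Compound 3 also stops at a limit. Compound 1 alone gives a number, 5400 nM. The change from compound 2 to the unmeasured compound 4, `O=C(CN1CCN(c2ccc(F)cc2)CC1)Nc1nc2c(s1)CCCC2`, is 4-fluorophenyl in place of pyridin-4-yl on an amine nitrogen in a ring. Among the measured compounds shown here, no measured pair shows this step, so its size is uncertain. Because compound 1 gives 5400 nM, compound 4 is expected to give a measurable number rather than stopping where compound 2 does, by a step that may still lie within the scatter. The estimate for compound 4 is 9000 nM, between 3000 nM and 25000 nM, an expected step of an at least 1.1-fold lower number from compound 2 to compound 4 (0.04 log units; that floor lies within the scatter).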

Compound 4, half-maximal inhibitory concentration: 4000 nM
Beside the measured number, compound 4's estimate is 2.3-fold (0.35 log units) above it; the measured number falls inside the stated range.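

In this assay, 4-fluorophenyl in place of pyridin-4-yl on an amine nitrogen in a ring gives an at least 2.5-fold lower number from compound 2 to compound 4 (0.39 log units; beyond the scatter). With the rest of the structure unchanged, the group at this position is enough to bring the read-out from a limit to a number. The full size of the step remains unknown because compound 2 gives only a limit: the limit of > 10000 nM in this assay, at which 2 of the 4 values shown sit.

The compounds shown leave open whether the fluorine itself matters, since a plain phenyl on this nitrogen does not appear among them. Going by these compounds, how a chlorophenyl or a methoxyphenyl would read there also remains open.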